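Tert-butyl on the pendant phenyl of a quinoline diamine

The compounds below may be only part of what the source reports. "The series", "measured", "known", "first", "only" and "open" are said of these compounds alone.

Measured compounds:
compound 1, `COc1ccc(F)cc1CNCCCNc1ccnc2cc(CCC(C)C)ccc12`, 9.47
compound 2, `COc1ccc(F)cc1CNCCCNc1ccnc2cc(Oc3ccc(C(C)(C)C)cc3)ccc12`, 9.28
compound 3, `COc1ccc(F)cc1CNCCCNc1ccnc2cc(-c3ccccc3)ccc12`, 9.47

Compound 3 carries a phenyl on the shared core where compound 1 has isopentyl and compound 2 has 4-(tert-butyl)phenoxy. In a physicochemical assay for acid dissociation, compound 3 matches compound 1 exactly at the digits given, and its value sits within the scatter of compound 2 as well: a number 0.19 log units higher from compound 2 to compound 3 (within the scatter). The other two steps among the measured set, a number 0.19 log units lower from compound 1 to compound 2 (within the scatter) and no change at the digits printed from compound 1 to compound 3 (within the scatter), likewise stay within the scatter. Exchanging the whole group on that aromatic carbon therefore leaves the acid dissociation constant essentially where it was.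

Compound 4, `COc1ccc(F)cc1CNCCCNc1ccnc2cc(-c3ccc(C(C)(C)C)cc3)ccc12`, has not been measured. It differs from compound 3 by tert-butyl in place of hydrogen on an aromatic carbon, placed on an aromatic carbon of a six-membered aromatic ring of carbon only, para to a large group. Since even the larger exchanges of isopentyl, phenyl and 4-(tert-butyl)phenoxy at the same part of the core moved nothing beyond the scatter, adding tert-butyl further out is expected to move nothing either. The expected step is a number 0.02 log units lower from compound 3 to compound 4 (within the scatter). For compound 4 the estimated value in this assay is 9.45, with a range from 9.15 to 9.75.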

Compound 4, acid dissociation constant: 9.47
The estimate for compound 4 lay 0.02 log units below the measured number, and the stated range covers the measured number.
By their numbers in this assay, from the lowest: compounds 2, 1, 3 and 4 (each within the scatter of the next).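

In this assay, among the compounds shown here, the step from hydrogen to tert-butyl on the phenyl is no change at the digits printed from compound 3 to compound 4 (within the scatter) and, unlike the earlier steps, which exchanged the whole group on the shared core, it changes that group only at its outer ring, para to a large group. The two other steps keep to the same picture: with 4-(tert-butyl)phenyl in place of 4-(tert-butyl)phenoxy the step is a number 0.19 log units higher from compound 2 to compound 4 (within the scatter) and stays within the scatter, while with 4-(tert-butyl)phenyl in place of isopentyl the step is no change at the digits printed from compound 1 to compound 4 (within the scatter) and also stays within the scatter. Nothing at hand bears on why the number holds across these four compounds.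

Tert-butyl is the only group seen on that ring carbon of the phenyl, so it remains open whether an amine, a carboxylic acid or a nitrile in the same place would also stay within the scatter in this assay. All four compounds also share the same amine chain, so what a longer chain there would do to the number is left open as well.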